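Piperazine chain in place of piperidine on the shared core

The source may hold more compounds than are shown below. What is called first, only, known or untested is meant among the compounds shown, and "the series" means these compounds.

For the measured compounds named here, compound 1 `c1ccc2c(c1)CN[C@@H](CN(CC[C@@H]1CCCNC1)[C@H]1CCCc3cccnc31)C2` gives 23% in an ADME assay on microsomes from liver (Mus musculus) for metabolic stability, read by LC-MS, with a stated time of 10 min, tested at 0.5 uM (a lower number here means that less of the compound is left, a higher number that more of the compound is left), the lowest of the three numbers so far. Compound 2 `CN1CCN(CCCN(C[C@H]2Cc3ccccc3CN2C)[C@H]2CCCc3cccnc32)CC1` gives 43% in this assay and compound 3 `c1cnc2c(c1)CCC[C@@H]2N(CCCN1CCNCC1)Cc1nc2ccccc2s1` gives 45%; both stand beyond the scatter above compound 1. Compound 4 `c1ccc2c(c1)CN[C@@H](CN(CCCCN1CCNCC1)[C@H]1CCCc3cccnc31)C2` differs from compound 1 in one place: 2-(piperazin-1-yl)ethyl in place of piperidin-3-yl on a saturated chain carbon, two bonds along the chain from an amine nitrogen. The entering chain, cut one bond further out, reads 3-(piperazin-1-yl)propyl, the chain that compound 3 also carries. Going by the values given here, no step between two measured compounds is available to size the move. Compound 4 is expected to sit higher than compound 1, a moderate step of a number 12 percentage points higher from compound 1 to compound 4 (beyond the scatter), resting on the value of compound 3 at 45%. Compound 4 is estimated at 35%, within 20% to 52%.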

Compound 4, percent of the compound remaining: 96%
Beside the measured number, compound 4's estimate is 61 percentage points below it; measured number outside the range, above it.
By their numbers in this assay, from the lowest: compound 1; then compounds 2 and 3 (each within the scatter of the next); then compound 4.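

At this place, on a saturated chain carbon, two bonds along the chain from an amine nitrogen, 2-(piperazin-1-yl)ethyl in place of piperidin-3-yl gives a number 73 percentage points higher from compound 1 to compound 4 (beyond the scatter) in this assay. For the compounds shown here, this is the first step that sizes a change here, and it shows that this one place alone can move the read-out strongly. No measurement at hand bears on the reason for the step.

The ring and the chain change together, so their shares remain unseparated. A 2-(piperidin-1-yl)ethyl or 2-(morpholin-4-yl)ethyl chain at this place would leave open questions answerable.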